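The source may hold more compounds than are shown below. What is called first, only, known or untested is meant among the compounds shown, and "the series" means these compounds.

Compound 1 `CCCCCC(=O)N1CCN(c2nnc3nncn3n2)CC1` gives 2960 nM in a functional assay on BeWo cells (Homo sapiens) for inhibition, read by MTT assay, with a stated time of 72 h; a lower number here means a stronger inhibitor, a higher number a weaker inhibitor. Compound 2 `CC(=O)N1CCN(c2nnc3nncn3n2)CC1` gives 13100 nM in this assay. Compound 3 `CN1CCN(c2nnc3nncn3n2)CC1` gives 7990 nM in this assay.

Among these three numbers compound 3 holds the second highest. Its nearest neighbour is compound 2, and that gap, a 1.6-fold lower number from compound 2 to compound 3 (0.21 log units; within the scatter), lies within the scatter, so the two cannot be told apart. The only separation beyond the scatter is to compound 1, a 2.7-fold higher number from compound 1 to compound 3 (0.43 log units; beyond the scatter).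

Compound 4 `CCC(=O)N1CCN(c2nnc3nncn3n2)CC1` differs from compound 3 in one place: propanoyl in place of methyl on an amine nitrogen in a ring. Within the data shown here, two measured steps bear on this. The comparison of compound 2 with compound 3 shows that an acetyl and a methyl on this ring nitrogen give numbers within the scatter of each other. The step of a 2.7-fold higher number from compound 1 to compound 3 (0.43 log units; beyond the scatter) shows that a pentylcarbonyl on the same nitrogen gives a clearly lower number than a methyl, and a 4.4-fold higher number from compound 1 to compound 2 (0.65 log units; beyond the scatter) shows that the chain on the carbonyl carbon is what carries that difference. Propanoyl sits between acetyl and pentylcarbonyl in chain length, so compound 4 is expected to show a modest lowering, a 1.2-fold lower number from compound 3 to compound 4 (0.09 log units; within the scatter), quite possibly still within the scatter. For compound 4 the estimate in this assay is 6500 nM, with a range from 2500 nM to 16000 nM.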

Compound 4, half-maximal inhibitory concentration: 13700 nM
Estimate against measurement, compound 4: 2.1-fold (0.32 log units) below; the range from low to high includes it.
By their numbers in this assay, from the lowest: compound 1; then compounds 3, 2 and 4 (each within the scatter of the next).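

The step of a 1.0-fold higher number from compound 2 to compound 4 (0.02 log units; within the scatter) shows that putting a methyl on the chain of the acetyl group makes no difference that can be detected in this assay, and the step of a 1.7-fold higher number from compound 3 to compound 4 (0.23 log units; within the scatter) likewise leaves propanoyl indistinguishable from a plain methyl on the same ring nitrogen. The methyl, acetyl and propanoyl compounds therefore form a single cluster, and a short acyl chain on this nitrogen is not enough to reach the number of compound 1, as the step of a 4.6-fold higher number from compound 1 to compound 4 (0.67 log units; beyond the scatter) shows by lying beyond the scatter. No measurement is available that explains why only the pentylcarbonyl group stands apart.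

The compounds shown leave open how long the chain must be before the number starts to drop, which a butanoyl or pentanoyl group on this nitrogen would help to settle, and whether a still longer chain, such as octanoyl, would lower it further. They also leave open whether the chain itself is needed, or whether a benzoyl group, with a ring on the carbonyl carbon, would serve equally well.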